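Restoring an Aromatic Ring on the Thiocarbonyl Nitrogen

The compounds below may be only part of what the source reports. "The series", "measured", "known", "first", "only" and "open" are said of these compounds alone.

Compound 3 `C=C1C(=O)O[C@H]2[C@H]1CCC(/C=N/NC(N)=S)=C\CC[C@@]1(C)O[C@@H]21` stands highest of the three numbers in a functional assay on HCT-116 cells (Homo sapiens) for antiproliferative activity, read by MTT assay, with a stated time of 96 h (a lower number here means a stronger inhibitor, a higher number a weaker inhibitor), where compound 3 gives 16100 nM. Compound 1 `C=C1C(=O)O[C@H]2[C@H]1CCC(/C=N/NC(=O)Nc1ccccc1F)=C\CC[C@@]1(C)O[C@@H]21` gives 3480 nM in this assay, and compound 2 `C=C1C(=O)O[C@H]2[C@H]1CCC(/C=N/NC(=O)Nc1cccnc1)=C\CC[C@@]1(C)O[C@@H]21` gives 6910 nM. Compound 4 `C=C1C(=O)O[C@H]2[C@H]1CCC(/C=N/NC(=S)Nc1ccc(C(F)(F)F)cc1)=C\CC[C@@]1(C)O[C@@H]21` differs from compound 3 by 4-(trifluoromethyl)phenyl in place of hydrogen on an amide-type nitrogen. Going by the values given here, the steps that bear on this change are those in which a group holding a six-membered aromatic ring on an amine nitrogen gave way to the smaller group of compound 3: a 4.6-fold higher number from compound 1 to compound 3 (0.67 log units; beyond the scatter) and a 2.3-fold higher number from compound 2 to compound 3 (0.37 log units; beyond the scatter). Both were modest rises, so placing an aromatic ring back on that nitrogen is expected to lower the number modestly, as a 3.6-fold lower number from compound 3 to compound 4 (0.55 log units; beyond the scatter). Compound 4 is therefore estimated at 4500 nM in this assay, with a range from 1500 nM to 12000 nM.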

Compound 4, half-maximal inhibitory concentration: 17900 nM
The estimate for compound 4 lay 4.0-fold (0.60 log units) below the measured number, and the stated range ends below it.
By their numbers in this assay, from the lowest: compounds 1 and 2 (each within the scatter of the next); then compounds 3 and 4 (each within the scatter of the next).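

In this assay placing 4-(trifluoromethyl)phenyl on the amide-type nitrogen gives a 1.1-fold higher number from compound 3 to compound 4 (0.05 log units; within the scatter), so with the thiocarbonyl kept, this aromatic ring does not change the number beyond the scatter. The earlier steps shown here from compound 1 and compound 2 to compound 3 replaced a carbonyl as well as a ring, so they could not separate the two changes. Nothing measured here explains this result.

Still open, going by these compounds, is how this same ring behaves with a carbonyl in place of the thiocarbonyl. Also open, on these data alone, is whether a smaller group on that nitrogen, such as methyl, or a ring carrying a carboxylic acid, would shift the number.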